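Smaller Aromatic Ring at the Benzylic Position: Compound 4

This account rests on a few compounds, and the source may have more. Where it says the series, first, only, none or still open, it means among the compounds named here.

Measured compounds:
- compound 1 `O=c1c(-c2cccc([N+](=O)[O-])c2)nc2ccccc2n1Cc1ccccc1`: 9 nM
- compound 2 `C=CCn1c(=O)c(-c2cccc([N+](=O)[O-])c2)nc2ccccc21`: 55 nM
- compound 3 `O=c1c(-c2cccc([N+](=O)[O-])c2)nc2ccccc2n1Cc1ccc2ccccc2c1`: 4300 nM

In an assay on cells for activation of Cystic fibrosis transmembrane conductance regulator (Homo sapiens), read by fluorescence, with a stated time of 10 min (on this read-out higher numbers stand for an effect only at larger amounts of compound and lower numbers for an effect already at smaller amounts), compound 3 gives the highest of the three numbers; its nearest neighbour is compound 2, and the difference a 78-fold higher number from compound 2 to compound 3 (1.89 log units; beyond the scatter) lies well beyond the scatter, while the gap a 480-fold higher number from compound 1 to compound 3 (2.68 log units; beyond the scatter) is larger still. Compound 4 `O=c1c(-c2cccc([N+](=O)[O-])c2)nc2ccccc2n1Cc1cccs1` differs from compound 3 at one place: thiophen-2-yl in place of naphthalen-2-yl on a saturated chain carbon bound to an aromatic nitrogen.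

Two measured steps speak to this change. The step from compound 1 to compound 3 shows that replacing phenyl by the larger naphthalen-2-yl raised the number greatly a 480-fold higher number from compound 1 to compound 3 (2.68 log units; beyond the scatter), and the step from compound 2 to compound 3 points the same way a 78-fold higher number from compound 2 to compound 3 (1.89 log units; beyond the scatter). Compound 4 moves back toward a single small aromatic ring, so a large drop in the number is expected, roughly a 220-fold lower number from compound 3 to compound 4 (2.33 log units; beyond the scatter).

Compound 4 is therefore estimated at 20 nM, with a range from 5 nM to 100 nM.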

Compound 4, half-maximal effective concentration: 10 nM
Beside the measured number, compound 4's estimate is 2.0-fold (0.30 log units) above it; measured number inside the range.
By their numbers in this assay, from the lowest: compounds 1 and 4 (each within the scatter of the next); then compound 2; then compound 3.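

In this assay, thiophen-2-yl serves as well as phenyl on the saturated chain carbon bound to an aromatic nitrogen: a 1.1-fold higher number from compound 1 to compound 4 (0.05 log units; within the scatter) stays within the scatter, so a five-membered aromatic ring containing sulfur and a six-membered ring of carbon only cannot be told apart here. The large penalty seen earlier therefore belongs to naphthalen-2-yl rather than to aromatic rings at this place in general, as a 430-fold lower number from compound 3 to compound 4 (2.63 log units; beyond the scatter) brings the number back to the level of the phenyl compound. With a 5.5-fold lower number from compound 2 to compound 4 (0.74 log units; beyond the scatter) beyond the scatter, both single aromatic rings shown here give lower numbers than the vinyl group.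

Going by these compounds, whether a furan-2-yl ring, a phenyl ring carrying an amine or a longer chain ending in phenyl would keep the number this low remains open. Nothing available explains these differences.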